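The compounds below may be only part of what the source reports. "The series", "measured", "known", "first", "only" and "open" are said of these compounds alone.

Measured compounds:
compound 1, `COC(=O)CC1CCN(C[C@H]2CN(c3ccc(-n4cc(-c5ccccn5)cn4)c(F)c3)C(=O)O2)CC1`: 224 ug/mL
compound 2, `O=C1O[C@@H](CN2CCC(c3ccc(F)cc3)CC2)CN1c1ccc(-n2cc(-c3ccccn3)cn2)c(F)c1`: > 400 ug/mL

Within the data shown here, in an ADME assay on HEK293-A cells (Homo sapiens) for cytotoxicity, read by MTT assay, with a stated time of 48 h (a higher number here means a weaker inhibitor, a lower number a stronger inhibitor), compound 1 gives 224 ug/mL, the only plain number among the two values shown. For compound 2 this assay reports only a limit of the assay, > 400 ug/mL. Compound 3, `O=C(OC[C@H]1CN(c2ccc(-n3cc(-c4ccccn4)cn3)c(F)c2)C(=O)O1)c1ccccc1`, differs from compound 1 in one place: benzoyloxy in place of 4-((methoxycarbonyl)methyl)piperidin-1-yl on a saturated chain carbon bound to a saturated ring carbon. Among the measured compounds shown here, the only measured step for comparison is an at least 1.7-fold higher number from compound 1 to compound 2 (0.25 log units; that floor lies within the scatter), a change on a saturated ring carbon that ends at a limit, namely (the limit of > 400 ug/mL in this assay, at which 1 of the 2 values shown sits), and whose floor lies within the scatter. That step concerns a different group at a different place, so it offers no more than a hint that such swaps leave this assay largely unchanged. A step of about a 1.2-fold higher number from compound 1 to compound 3 (0.06 log units; within the scatter) is therefore expected, with no change beyond the scatter. Compound 3 is estimated at 260 ug/mL, within 130 ug/mL to 400 ug/mL.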

Compound 3, half-maximal inhibitory concentration: > 400 ug/mL
Compound 3: no number, only a limit (the forecaster's own chance of this, stated with the estimate: 35%); middle value at least 1.5-fold (0.18 log units) away from the limit.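

Compound 3 is the first change shown at a saturated chain carbon bound to a saturated ring carbon, where benzoyloxy replaces the whole 4-((methoxycarbonyl)methyl)piperidin-1-yl group, including its ring nitrogen. In this assay compound 3 gives only a limit of the assay, > 400 ug/mL. The swap gives an at least 1.7-fold higher number from compound 1 to compound 3 (0.25 log units; that floor lies within the scatter), so this large exchange at this place brings no lower number, yet it cannot be called a true rise either.

How far compound 2 and compound 3 actually lie past that limit stays hidden: the limit of > 400 ug/mL in this assay, at which 2 of the 3 values shown sit. Also open, going by these compounds, is whether a carboxylic acid or a primary amine at this place would shift the number in this assay beyond the scatter.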